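Swapping an Amine for an Aryl Group on the Carbonyl

The source may hold more compounds than are shown below. What is called first, only, known or untested is meant among the compounds shown, and "the series" means these compounds.

Of the compounds shown here, three have been tested so far in a functional assay on OVCAR-3 cells (Homo sapiens) for inhibition, read by sulforhodamine B assay, with a stated time of 48 h, tested at 100 uM; on this read-out lower numbers stand for a stronger effect and higher numbers for a weaker effect at the one concentration tested. Compound 1 `O=C(Nc1cccc(-n2cc(-c3ccncc3)c(-c3cc(O)cc(Cl)c3)n2)c1)Nc1ccc(Cl)c(Cl)c1` gives -20%, compound 2 `COc1cc(Cl)cc(-c2nn(-c3cccc(NC(=O)Nc4cc(C(F)(F)F)cc(C(F)(F)F)c4)c3)cc2-c2ccncc2)c1` gives -81%, and compound 3 `COc1cc(Cl)cc(-c2nn(-c3cccc(NC(=O)Nc4ccc(Cl)c(Cl)c4)c3)cc2-c2ccncc2)c1` gives -4%. Among the compounds with values here, compound 3 therefore stands highest of the three numbers, meaning the weakest effect at the single concentration tested; the one measured step leading to it, a number 16 percentage points higher from compound 1 to compound 3 (beyond the scatter), is modest.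

Compound 4 `COc1cc(Cl)cc(-c2nn(-c3cccc(NC(=O)c4cccc(C(F)(F)F)c4)c3)cc2-c2ccncc2)c1` differs from compound 3 in one place: 3-(trifluoromethyl)phenyl in place of (3,4-dichlorophenyl)amino on a carbonyl carbon. Within the data shown here, no measured step bears directly on this change. The nearest comparison is compound 2, which carries a different aromatic group at the same end of the molecule and shows a far lower number than compound 3, but it keeps the amino link that compound 4 loses, so it only hints that this end of the molecule can move the read-out a long way. The expected step of a number 26 percentage points lower from compound 3 to compound 4 (beyond the scatter) is therefore uncertain in size but more likely downward than not. Compound 4 is estimated at -30%, within -75% to 5%.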

Compound 4, a percentage reported as activity, at one concentration (the size of the read-out at that concentration, not a potency): 38%
Compound 4: middle estimate off by 68 percentage points, on the low side, and the stated range ends below it.
By their numbers in this assay, from the lowest: compound 2; then compound 1; then compound 3; then compound 4.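

In this assay, within the data shown here, the step of a number 42 percentage points higher from compound 3 to compound 4 (beyond the scatter) is the first here to carry the number far upward, towards a weaker effect at the one concentration tested. With compound 2 at -81% and compound 4 at 38% on either side of compound 3, the group on this carbonyl carbon spans a wide range of the read-out, from either direction of compound 3. Nothing on hand explains why this change has such a large effect.

The change removes the amino link and alters the ring's substituents at once, so the compounds shown cannot separate the two contributions. Open too, on these data alone, is what (3-(trifluoromethyl)phenyl)amino or a simple methyl would do on the same carbonyl carbon.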